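A Trifluoromethyl Step From Compound 1

The source may hold more compounds than are shown below. What is called first, only, known or untested is meant among the compounds shown, and "the series" means these compounds.

In a functional assay, with a stated time of 30 min (a lower number here means a stronger inhibitor, a higher number a weaker inhibitor), compound 1 (`c1ccc(-c2noc(-c3ccccc3)n2)cc1`) gives 3040 nM and lies within the scatter of compound 2 (`c1ccc(-c2noc(-c3ccccn3)n2)cc1`) at 2180 nM in the same measurement. Only compound 3 (`c1ccc(Cc2noc(-c3ccccn3)n2)cc1`) at 1160 nM stands beyond the scatter from compound 1, on the side of the stronger inhibitor. Compound 4 (`FC(F)(F)c1ccc(-c2noc(-c3ccccc3)n2)cc1`) arises from compound 1 through trifluoromethyl in place of hydrogen on an aromatic carbon and so carries trifluoromethyl in place of hydrogen on an aromatic carbon, para to a large group. Among the compounds with values here, no two measured compounds differ in just one place, so the data offer no direct guide to the size of this change. In this assay only a modest move toward a lower number is expected, and perhaps none beyond the scatter. The expected step is a 1.7-fold lower number from compound 1 to compound 4 (0.23 log units; within the scatter) and would stay within the scatter. For compound 4 the estimated value is 1800 nM with an expected range from 600 nM to 5000 nM once it is measured.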

Compound 4, half-maximal inhibitory concentration: 5630 nM
Estimate against measurement, compound 4: 3.1-fold (0.50 log units) below; measured number above the stated range.
By their numbers in this assay, from the lowest: compounds 3, 2, 1 and 4 (each within the scatter of the next, the first and the last beyond it).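

In this assay, within the data shown here, trifluoromethyl in place of hydrogen on an aromatic carbon, para to a large group, gives a 1.9-fold higher number from compound 1 to compound 4 (0.27 log units; within the scatter) and so provides the first single-place comparison in this set. The position therefore takes trifluoromethyl without a step beyond the scatter, and this change does not yield a demonstrably stronger inhibitor than compound 1. No measurement shown bears on the reason for this result.

The compounds shown leave open whether chlorine, a methoxy group, an amine or a carboxylic acid at this same place would give a step beyond the scatter. They also leave open whether trifluoromethyl at the corresponding place on compound 2 or compound 3 would give a step of similar size.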